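Hydroxy removal on the amide-bearing ring of two anilide cores

The compounds below may be only part of what the source reports. "The series", "measured", "known", "first", "only" and "open" are said of these compounds alone.

Compound 1 `O=C(Nc1cccc2cccnc12)c1cc(Br)cnc1O` carries a hydroxy on the amide-bearing ring and in a functional assay on HUVEC cells (Homo sapiens) for inhibition, read by ELISA and BrdU incorporation (on this read-out lower numbers stand for stronger inhibition and higher numbers for weaker inhibition), compound 1 gives 12.9 nM. Compound 2 `O=C(Nc1cccc2cccnc12)c1cncc(Br)c1` lacks that group; in this assay compound 2 gives 211 nM, so that a 16-fold higher number from compound 1 to compound 2 (1.21 log units; beyond the scatter). The change is hydrogen in place of hydroxy on an aromatic carbon. Compound 3 `Cc1cc(Br)cc(C(=O)Nc2cnc3ccccc3c2)c1O` sits on a different core, and the difference between the two cores is not broken down here; in this assay compound 3 gives 18.9 nM. Compound 4 `Cc1cc(Br)cc(C(=O)Nc2cnc3ccccc3c2)c1` is not yet measured; it differs from compound 3 by hydrogen in place of hydroxy on an aromatic carbon. This is the same kind of change as from compound 1 to compound 2, though the surroundings differ: here the ring is of carbon only and the site is ortho to a methyl group, rather than in a ring with one nitrogen and next to the ring nitrogen. A loss of similar size is expected, resting on the step from compound 1 to compound 2, so the estimated step is a 10-fold higher number from compound 3 to compound 4 (1.00 log units; beyond the scatter). For compound 4 in this assay the expected value is 190 nM, estimated between 60 nM and 600 nM.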

Compound 4, half-maximal inhibitory concentration: 89.6 nM
Beside the measured number, compound 4's estimate is 2.1-fold (0.33 log units) above it; the measured number falls inside the stated range.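

In this assay, hydrogen in place of hydroxy gives a 4.7-fold higher number from compound 3 to compound 4 (0.68 log units; beyond the scatter), so the direction of the step seen on the core of compound 1 carries over to the core of compound 3. The size of the step does not carry over: the same change on two cores in this assay, a 16-fold higher number (1.21 log units; beyond the scatter) from compound 1 to compound 2 and a 4.7-fold higher number (0.68 log units; beyond the scatter) from compound 3 to compound 4, 3.5-fold (0.54 log units) apart, beyond the scatter of two such steps. With one step on each core, these data do not show which difference between the cores goes with the different sizes, and two cores support no rule for the whole series.

Open, from the compounds shown here alone, is whether a methoxy or an amine in place of the hydroxy would keep the numbers of compound 1 and compound 3. Also open, going by these compounds, is whether the methyl group or the bromo group of compound 3 has any part in the size of the step.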